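The compounds below may be only part of what the source reports. "The series", "measured", "known", "first", "only" and "open" are said of these compounds alone.

In a functional assay on CCRF-CEM cells (Homo sapiens) (on this read-out higher numbers stand for weaker inhibition and lower numbers for stronger inhibition), compound 1 (`O=C(/C=C/c1ccc(F)cc1)Oc1ccc(/C=C2\CCCCC2=O)cc1`) gives 14400 nM and compound 2 (`Cc1ccc(/C=C/C(=O)Oc2ccc(/C=C3\CCCC(CN(C)C)C3=O)cc2)cc1`) gives 7020 nM. Compound 2 thus holds the lower of the two numbers, by a gap just beyond the scatter. Compound 3 (`CN(C)CC1CCC/C(=C\c2ccc(OC(=O)/C=C/c3ccc(F)cc3)cc2)C1=O`) differs from compound 2 in one place: fluoro in place of methyl on an aromatic carbon, with fluoro in place of methyl on an aromatic carbon, para to a large group. Within the data shown here, no step between measured compounds covers this change, and no shift beyond the scatter is expected in this assay. The expected change is an estimated 1.0-fold lower number from compound 2 to compound 3 (0.00 log units; within the scatter). Compound 3 is expected at 7000 nM, with an estimated range of 3000 nM to 15000 nM.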

Compound 3, half-maximal inhibitory concentration: 6000 nM
The estimate for compound 3 lay 1.2-fold (0.07 log units) above the measured number; the range from low to high includes it.
By their numbers in this assay, from the lowest: compounds 3 and 2 (each within the scatter of the next); then compound 1.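

In this assay, the change from 4-methylphenyl to 4-fluorophenyl gives a 1.2-fold lower number from compound 2 to compound 3 (0.07 log units; within the scatter), so methyl and fluoro cannot be told apart at this aromatic carbon. Among these compounds, compound 3 also allows the first single-place reading of (dimethylamino)methyl in place of hydrogen on the saturated ring carbon, a modest step of a 2.4-fold lower number from compound 1 to compound 3 (0.38 log units; beyond the scatter). Nothing measured here offers a reason for either step. From the compounds shown here alone, it remains open whether a chloro or methoxy group on that aromatic carbon would read like fluoro and methyl, and whether a morpholine or pyrrolidine in place of the dimethylamino group would keep the step.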